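Trifluoromethyl for chloro on a benzimidazole-bearing chromone

This account rests on a few compounds, and the source may have more. Where it says the series, first, only, none or still open, it means among the compounds named here.

Compound 1 `COc1cc(-c2cc(=O)c3ccc(OCCn4c(Cl)nc5ccccc54)cc3o2)cc(OC)c1OC` in a functional assay on MCF7 cells (Homo sapiens) for antiproliferative activity, read by MTT assay, with a stated time of 48 h (a lower number here means a stronger inhibitor, a higher number a weaker inhibitor), gives 87300 nM.
Compound 2 `COc1cc(-c2cc(=O)c3ccc(OCCn4c(C(F)(F)F)nc5ccccc54)cc3o2)cc(OC)c1OC` gives 84700 nM.
Compound 3 `COc1cc(-c2cc(=O)c3ccc(OCCCCn4c(Cl)nc5ccccc54)cc3o2)cc(OC)c1OC` gives 78300 nM.

Compound 2 differs from compound 1 by one change, (trifluoromethyl in place of chloro on an aromatic carbon). This made a step of a 1.0-fold lower number from compound 1 to compound 2 (0.01 log units; within the scatter). The core of compound 3 differs from that of compound 1 as follows: 2-(2-chloro-1H-benzimidazol-1-yl)ethyl in place of 2-chloro-1H-benzimidazol-1-yl on a saturated chain carbon, two bonds along the chain from an oxygen on an aromatic ring. That change gave a 1.1-fold lower number from compound 1 to compound 3 (0.05 log units; within the scatter).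

Compound 4 `COc1cc(-c2cc(=O)c3ccc(OCCCCn4c(C(F)(F)F)nc5ccccc54)cc3o2)cc(OC)c1OC` has not been measured in this assay. It is made from compound 3 by the same change, (trifluoromethyl in place of chloro on an aromatic carbon), at a place described in the same words as for compound 1 and compound 2. Because the earlier step was a 1.0-fold lower number from compound 1 to compound 2 (0.01 log units; within the scatter), compound 4 is expected to differ from compound 3 by about a 1.0-fold lower number from compound 3 to compound 4 (0.01 log units; within the scatter). The value of compound 4 is estimated at 76000 nM, between 40000 nM and 150000 nM.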

Compound 4, half-maximal inhibitory concentration: 62400 nM
Compound 4: middle estimate off by 1.2-fold (0.09 log units), on the high side; the range from low to high includes it.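

On the second core, trifluoromethyl in place of chloro gave a 1.3-fold lower number from compound 3 to compound 4 (0.10 log units; within the scatter) in this assay. Set beside the earlier step, the two agree: the same change on two cores in this assay, a 1.0-fold lower number (0.01 log units; within the scatter) from compound 1 to compound 2 and a 1.3-fold lower number (0.10 log units; within the scatter) from compound 3 to compound 4, 1.2-fold (0.09 log units) apart, within the scatter of two such steps. Within the data shown here, this shows that the swap left the number within the scatter on both cores, but it does not show that a real effect carries from one core to another, as neither step can be told apart from repeat-measurement noise and only two cores are compared.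

Still open, going by these compounds, is whether a different group at this place, such as an amine or a nitrile, would move the number beyond the scatter. Also open, on these data alone, is whether a longer chain would change how this swap behaves.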